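The source may hold more compounds than are shown below. What is called first, only, known or untested is meant among the compounds shown, and "the series" means these compounds.

Compound 1 `CCOCCOc1cccc2ccc(N)nc12` gives in an assay on cells with melanin-concentrating hormone receptor 1 (Homo sapiens) as the target, read by radioligand binding; a lower number here means a stronger inhibitor, a higher number a weaker inhibitor > 2000 nM, which is a limit of the assay and not a number.
Compound 2 `CC#CCCOc1cccc2ccc(N)nc12` gives in this assay > 2000 nM, again a limit rather than a number.
Compound 3 `Nc1ccc2cccc(OCCC3CC3)c2n1` gives in this assay 492 nM.

Among the compounds with values here, compound 3 therefore holds the only real number of the three, the other two sitting at the limit of > 2000 nM in this assay, at which 2 of the 3 values shown sit. Compound 4 `Nc1ccc2cccc(OCC3CCCO3)c2n1` has not yet been measured in this assay; it differs from compound 3 in one place: oxolan-2-yl in place of cyclopropylmethyl on a saturated chain carbon bound to an oxygen on an aromatic ring.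

Within the data shown here, the steps that bear on this are an at least 4.0-fold lower number from compound 1 to compound 3 (0.60 log units; beyond the scatter) and an at least 4.0-fold lower number from compound 2 to compound 3 (0.60 log units; beyond the scatter), both at least modest and beyond the scatter, while a step that the two limits leave unreadable from compound 1 to compound 2 cannot be read. Both readable steps show that the cyclopropyl-bearing chain of compound 3 gave a lower number than chains carrying ethoxy or prop-1-yn-1-yl. Compound 4 trades the cyclopropylmethyl for oxolan-2-yl, a ring that brings one hydrogen-bond acceptor, more like the oxygen-containing chain of compound 1 than the chain of compound 3. For compound 4 a higher number is therefore expected, estimated at 1500 nM with a range from 400 nM to 5000 nM, meaning an expected 3.0-fold higher number from compound 3 to compound 4 (0.48 log units; beyond the scatter), with a fair chance that only a limit is reported.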

Compound 4, half-maximal inhibitory concentration: > 2000 nM
Compound 4: no number, only a limit; the forecaster's own chance of this, stated with the estimate: 45%; middle value at least 1.3-fold (0.12 log units) from the limit.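

In this assay, a ring at this place does not by itself preserve the result seen with the cyclopropyl-bearing chain: oxolan-2-yl in place of cyclopropylmethyl gives an at least 4.0-fold higher number from compound 3 to compound 4 (0.60 log units; beyond the scatter). Compound 4 gives only a limit of the assay and not a number: the limit of > 2000 nM in this assay, at which 3 of the 4 values shown sit. The steps linking compound 4 to compound 1 and compound 2 cannot be read, since each has a limit at both ends, so these three chains cannot be ranked against one another.

The compounds shown do not separate the oxygen in the oxolan-2-yl ring from the size of that ring, since the two change together. A cyclopentyl group, a five-membered ring of carbon only, would pull these two changes apart, and a cyclobutyl group would test the ring size between the two rings shown.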